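The source may report more compounds than this note shows. Statements on the series, on what has been measured and on what is new or still open speak of the compounds shown alone.

Measured so far:
compound 1 `O=S(=O)(/C=C/c1ccccc1F)c1ccccn1`: 98.6%
compound 2 `O=S(=O)(/C=C/c1ccccc1F)c1ncccc1C(F)(F)F`: 100%

Among the compounds with values here, in an ADME assay on BV-2 cells (Mus musculus) for cytotoxicity, with a stated time of 24 h, tested at 50 uM (a higher number here means a weaker effect of the compound at the concentration tested, a lower number a stronger effect), compound 2 gives 100%, the upper of the two numbers, but the only measured step is small: a number 1.4 percentage points higher from compound 1 to compound 2 (within the scatter). Compound 3 `O=S(=O)(/C=C/c1ncccc1F)c1ncccc1C(F)(F)F` is not yet measured; it differs from compound 2 in one place: 3-fluoropyridin-2-yl in place of 2-fluorophenyl on a double-bonded chain carbon bound to a double-bonded chain carbon. Within the data shown here, that measured step changed a different part of the shared core, so no step bears directly on this change. Both measured compounds sit near the top of the scale, and compound 3 is therefore expected to show no step beyond the scatter, a number 1 percentage points lower from compound 2 to compound 3 (within the scatter). For compound 3 the estimate is 99%, with a range from 90% to 100%.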

Compound 3, a percentage reported as activity, at one concentration (the size of the read-out at that concentration, not a potency): 84.1%
Beside the measured number, compound 3's estimate is 14.9 percentage points above it; the measured number lies below the stated range.
By their numbers in this assay, from the lowest: compound 3; then compounds 1 and 2 (each within the scatter of the next).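

In this assay, the group on this double-bonded chain carbon can shift the read-out: 3-fluoropyridin-2-yl in place of 2-fluorophenyl gives a number 15.9 percentage points lower from compound 2 to compound 3 (beyond the scatter). Within the data shown here, the earlier trifluoromethyl change stayed within the scatter, so this is the first step to show a stronger effect at the concentration tested. Nothing available here explains this step. Going by these compounds, it remains open whether the same ring change would give a similar step on the core of compound 1. Also open, on these data alone, is how an amine or a methoxy group in place of the fluorine would read out.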